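A few compounds are considered here, and "the series" means these few. Any claim that something is new, unique, unknown or untested is made for them only; others in the source may bear on it.

Working notes on the series, with every reading taken from a functional assay on MCF7 cells (Homo sapiens) for antiproliferative activity, read by MTT assay, with a stated time of 48 h (a higher number here means a weaker inhibitor, a lower number a stronger inhibitor), as the sole measure so far. Compound 1 (`CC(=O)OC/C1=C/C[C@](C)(CCC=C(C)C)/C=C/[C@@H](OC(=O)C=C(C)C)[C@](C)(OC(C)=O)/C=C/C1=O`) reads 3990 nM and compound 3 (`C=C1/C=C/C(=O)/C(CO)=C\C[C@](C)(CCC=C(C)C)/C=C/[C@H]1OC(=O)C=C(C)C`) reads 2750 nM on the same scale. Compound 2 (`COC/C1=C/C[C@](C)(CCC=C(C)C)/C=C/[C@@H](OC(=O)C=C(C)C)[C@](C)(O)/C=C/C1=O`) reads 4130 nM and stands within the scatter of both of the others, so the three values show no separation.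

Compound 4 (`CC(C)=CCC[C@]1(C)/C=C/[C@@H](OC(=O)C=C(C)C)[C@](C)(O)/C=C/C(=O)/C(CN(C)C)=C\C1`) has not yet been measured. It departs from compound 2 in one place: dimethylamino in place of methoxy on a saturated chain carbon bound to a double-bonded ring carbon. In words, this is dimethylamino in place of methoxy on a saturated chain carbon bound to a double-bonded ring carbon.

For the measured compounds named here, no pair of measured compounds differs in one place alone, so the data hold no direct precedent for this exchange. Going by the values given here, the only guide is the tight grouping of the three values, with compound 2 at 4130 nM as the starting point. On that basis, no step beyond the scatter is expected in this assay and no direction is favoured. The expected change is a 1.2-fold lower number from compound 2 to compound 4 (0.07 log units; within the scatter) and this estimate lies within the scatter. For compound 4 the estimated value is 3500 nM with a range of 1500 nM to 8000 nM expected to hold the measurement.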

Compound 4, half-maximal inhibitory concentration: 690 nM
Estimate against measurement, compound 4: 5.1-fold (0.71 log units) above; the measured number lies below the stated range.
By their numbers in this assay, from the lowest: compound 4; then compounds 3, 1 and 2 (each within the scatter of the next).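

In this assay, for the compounds shown here, dimethylamino in place of methoxy on a saturated chain carbon bound to a double-bonded ring carbon gives a 6.0-fold lower number from compound 2 to compound 4 (0.78 log units; beyond the scatter), and this is the only one-place step so far. Going by these compounds alone, the close readings of the earlier compounds, none of which formed a one-place pair, gave no sign that this position could move the reading; this pair shows that a change here alone, read one bond further out as methoxymethyl to (dimethylamino)methyl, is enough to do so. No measured evidence bears on what lies behind the step, so it stands as an observation on this one pair.

The compounds shown leave open whether the step is particular to dimethylamino or extends to other groups at this place, such as a primary amine, pyrrolidine, morpholine or a carboxylic acid. They also leave open whether the same exchange gives a step of similar size with the rest of the structure changed, for instance with an acetate in place of the hydroxyl of compound 4.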